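A Fluoro-to-Trifluoromethyl Step in a Cytotoxicity Series

This account rests on a few compounds, and the source may have more. Where it says the series, first, only, none or still open, it means among the compounds named here.

Values measured so far in an ADME assay on Vero cells (Chlorocebus sabaeus) for cytotoxicity, read by resazurin assay, with a stated time of 72 h (a higher number here means a weaker inhibitor, a lower number a stronger inhibitor), are these

Compound 1 (`COc1ccc(C(=O)CCN2CCN(c3ccc(C(F)(F)F)cc3)CC2)cc1`) gives 135000 nM
Compound 2 (`COc1ccc(C(=O)CCN2CCN(c3ccc(F)cc3)CC2)cc1OC`) gives 175000 nM

Compound 2 stands within the usual scatter of compound 1, so the two measured compounds cannot be told apart in this assay on these numbers. Compound 3 (`COc1ccc(C(=O)CCN2CCN(c3ccc(C(F)(F)F)cc3)CC2)cc1OC`) has not yet been measured. It departs from compound 2 by trifluoromethyl in place of fluoro on an aromatic carbon, para to a large group (trifluoromethyl in place of fluoro on an aromatic carbon). Going by the values given here, no step between measured compounds isolates this change. Still, compound 1 also carries trifluoromethyl, and its value of 135000 nM lies within the scatter of compound 2 (175000 nM). No change beyond the scatter is therefore expected, and the estimated step is a 1.3-fold lower number from compound 2 to compound 3 (0.10 log units; within the scatter) in size. For compound 3 the expected value is 140000 nM, with an estimated range from 70000 nM to 260000 nM overall.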

Compound 3, half-maximal inhibitory concentration: 243000 nM
Compound 3: middle estimate off by 1.7-fold (0.24 log units), on the low side; low and high end bracket the measured number.
By their numbers in this assay, from the lowest: compounds 1, 2 and 3 (each within the scatter of the next).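

Going by these compounds alone, with compound 3 in hand, trifluoromethyl in place of fluoro on an aromatic carbon, para to a large group, has a step of its own in this assay for the first time, and this step, a 1.4-fold higher number from compound 2 to compound 3 (0.14 log units; within the scatter), shows that the exchange does not separate the two compounds. Methoxy in place of hydrogen on an aromatic carbon can now also be read on its own, and that step, a 1.8-fold higher number from compound 1 to compound 3 (0.26 log units; within the scatter), likewise does not separate the two compounds. No supporting measurement bears on either step.

On these data alone, only fluoro and trifluoromethyl are seen at this position, so it remains open whether an amine, a nitrile or a carboxylic acid there would give a step beyond the scatter. As far as these compounds go, whether ethoxy in place of methoxy would do so also remains open.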